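Chloro in place of nitro on the 3-nitrophenyl compound

The source may report more compounds than this note shows. Statements on the series, on what has been measured and on what is new or still open speak of the compounds shown alone.

In a functional assay on HT-29 cells (Homo sapiens) for antiproliferative activity, read by MTT assay, with a stated time of 24 h (on this read-out higher numbers stand for weaker inhibition and lower numbers for stronger inhibition), compound 3 `COc1ccc(C(=O)/C=C/c2cccc([N+](=O)[O-])c2)c2c1C=CC(C)(C)O2` gives 4260 nM. Compound 2 `COc1ccc(C(=O)/C=C/c2ccc([N+](=O)[O-])cc2)c2c1C=CC(C)(C)O2` gives 3730 nM, and the step of a 1.1-fold higher number from compound 2 to compound 3 (0.06 log units; within the scatter) shows no separation of the two. Compound 1 `COc1ccc(/C=C/C(=O)c2ccc(OC)c3c2OC(C)(C)C=C3)c(F)c1` reads > 10000 nM, which is a limit of the assay. Both steps from that limit, an at least 2.6-fold lower number from compound 1 to compound 2 (0.42 log units; beyond the scatter) and an at least 2.3-fold lower number from compound 1 to compound 3 (0.37 log units; beyond the scatter), are modest at minimum.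

Compound 4 `COc1ccc(C(=O)/C=C/c2cccc(Cl)c2)c2c1C=CC(C)(C)O2` has chloro in place of nitro on an aromatic carbon, meta to a large group: chloro in place of nitro on an aromatic carbon. Within the data shown here, no measured step exchanges nitro for chloro. The step of a 1.1-fold higher number from compound 2 to compound 3 (0.06 log units; within the scatter) leaves nitro in the molecule, and an at least 2.3-fold lower number from compound 1 to compound 3 (0.37 log units; beyond the scatter) replaces a whole aryl group, so no step beyond the scatter is expected in this assay. The expected step is a 1.1-fold higher number from compound 3 to compound 4 (0.05 log units; within the scatter). For compound 4 the estimated value is 4800 nM, with an expected range of 2000 nM to 10000 nM.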

Compound 4, half-maximal inhibitory concentration: > 10000 nM
Compound 4: a limit, no number; the forecaster's own chance of this, stated with the estimate: 15%; at least 2.0-fold (0.31 log units) between middle value and limit.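

Among these compounds, replacing the group at this position, an aromatic carbon meta to a large group, does register in this assay: the change to chloro gives an at least 2.3-fold higher number from compound 3 to compound 4 (0.37 log units; beyond the scatter), the first step beyond the scatter that alters only this substituent. The 3-chlorophenyl compound also separates from the 4-nitrophenyl compound, with an at least 2.6-fold higher number from compound 2 to compound 4 (0.42 log units; beyond the scatter), so within these compounds, readings below the limit occur only with nitro present. The step between compound 1 and compound 4 cannot be read, as both values are limits: the limit of > 10000 nM in this assay, at which 2 of the 4 values shown sit.

From the compounds shown here alone, how far compound 4 lies past its limit stays open. Also open, going by these compounds, is whether an amine or a carboxylic acid at this position would give a reading like that of compound 3.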